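Cyano Removed: Cytotoxicity Expected for Compound 4

The source may report more compounds than this note shows. Statements on the series, on what has been measured and on what is new or still open speak of the compounds shown alone.

Of the compounds shown here, three that share one core have been tested in an ADME assay on HEL cells (Homo sapiens) for cytotoxicity, read by microscopy; on this read-out lower numbers stand for higher toxicity in this test and higher numbers for lower toxicity in this test. Compound 1 `Cc1ccccc1OCCCCCn1ccc(=O)[nH]c1=O` reports a limit of the assay in this assay, > 100000 nM. Compound 2 `CCCOC(=O)c1ccc(OCCCCCn2ccc(=O)[nH]c2=O)cc1` likewise reports a limit in this assay, >= 100000 nM. Among the measured compounds shown here, compound 3 `N#Cc1ccc(OCCCCCn2ccc(=O)[nH]c2=O)cc1` is the one compound that gives an actual number in this assay, 100000 nM. For the measured compounds named here, the two other results are limits of the assay, so compound 3 stands alone as the single measured value. Going by the values given here, the only step between measured compounds, a number no higher from compound 2 to compound 3 (the limit leaves the size open), shows a result that does not rise, but its size cannot be read. The lines the limit of > 100000 nM in this assay, at which 1 of the 3 values shown sits, and the limit of >= 100000 nM in this assay, at which 1 of the 3 values shown sits, mark the limits at which compounds 1 and 2 sit.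

Compound 4 `O=c1ccn(CCCCCOc2ccccc2)c(=O)[nH]1` is not yet measured in this assay. It differs from compound 3 by hydrogen in place of cyano on an aromatic carbon. Among the compounds with values here, the one measured step leaves its size open, and every result so far sits at or above the same level, so no change beyond the usual scatter is expected in either direction. Compound 4 is therefore expected to give about 100000 nM, between 50000 nM and 200000 nM. The step of no change at the digits printed from compound 3 to compound 4 (within the scatter) is expected to stay within the scatter, with a good chance that only a limit is reported.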

Compound 4, minimum cytotoxic concentration: > 100000 nM
Compound 4 was reported as a limit; the forecaster's own chance of this, stated with the estimate: 60%; the middle value sits exactly at the limit.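

In this assay, swapping the nitrile for hydrogen on the aromatic carbon gives a number no lower from compound 3 to compound 4 (the limit leaves the size open). Compound 3 had left unclear whether that group was needed to reach this level of low toxicity, and the bare ring of compound 4 shows that it is not: with only hydrogen at this position, the read-out does not drop. The steps to compound 4 from compound 1 and from compound 2 cannot be read, as both ends of each step are limits of the assay, and the results now gather at the top of what the test reports: the limit of > 100000 nM in this assay, at which 2 of the 4 values shown sit.

From the compounds shown here alone, the true values of compound 1, compound 2 and compound 4 remain unknown, so these three cannot be ranked against each other or placed exactly against compound 3. Going by these compounds, it also remains open whether an amine, a carboxylic acid or a longer chain on this same aromatic carbon would bring the read-out down to a measurable number.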